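The source may report more compounds than this note shows. Statements on the series, on what has been measured and on what is new or still open speak of the compounds shown alone.

Measured in a functional assay on SK-BR-3 cells (Homo sapiens) for antiproliferative activity, read by MTT assay, with a stated time of 72 h; a higher number here means a weaker inhibitor, a lower number a stronger inhibitor:
compound 1 `C/C=C1/[C@H](O[C@@H]2O[C@H](CO)[C@@H](O)[C@H](O)[C@H]2O)OC=C(C(=O)OC)[C@H]1CC(=O)OCCc1ccc2c(c1)OCCO2` gives > 20000 nM
compound 2 `C/C=C1/[C@H](O[C@@H]2O[C@H](CO)[C@@H](O)[C@H](O)[C@H]2O)OC=C(C(=O)OC)[C@H]1CC(=O)OCCCc1ccc(OC)c(OC)c1` gives > 20000 nM

Compound 2 stands at > 20000 nM, which is a limit of this assay and not a number. Compound 1 gives > 20000 nM, which is also a limit. Among the compounds with values here, the one measured step, a step that the two limits leave unreadable from compound 1 to compound 2, has no readable size, and it is the only step that bears on what follows. Compound 3 `C#CCOC(=O)C[C@@H]1C(C(=O)OC)=CO[C@@H](O[C@@H]2O[C@H](CO)[C@@H](O)[C@H](O)[C@H]2O)/C1=C/C` differs from compound 2 by ethynyl in place of 2-(3,4-dimethoxyphenyl)ethyl on a saturated chain carbon bound to an oxygen next to a carbonyl group, with ethynyl in place of 2-(3,4-dimethoxyphenyl)ethyl on a saturated chain carbon bound to an oxygen next to a carbonyl group. Within the data shown here, no measured step covers this change. With the limit of > 20000 nM in this assay, at which 2 of the 2 values shown sit, and compound 2 at > 20000 nM, compound 3 is expected to show no step beyond the scatter in this assay. The expected move is a step that the limit leaves unreadable from compound 2 to compound 3. For compound 3 the estimated value is 25000 nM, with an expected range from 10000 nM to 60000 nM.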

Compound 3, half-maximal inhibitory concentration: > 15000 nM
Compound 3: only a limit was reported (the forecaster's own chance of this, stated with the estimate: 85%); the middle value does not contradict the limit.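

In this assay, within the data shown here, compound 1, compound 2 and compound 3 are all reported only as limits, and no step among them can be read. The compounds shown leave open whether any group at this place on the shared core gives a measured value rather than a limit.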